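The compounds below may be only part of what the source reports. "The series", "measured", "known", "first", "only" and "open" are said of these compounds alone.

Working notes on the series. For the measured compounds named here, compound 1 `COc1ccc(CN(C(=O)Nc2ccc(C)cc2)n2cnnc2)cc1OC` and compound 2 `O=C(NCc1ccccc1)N(Cc1ccccn1)n1cnnc1` are the two measured members. In a functional assay on B16-F10 cells (Mus musculus) for cytotoxicity, read by MTT assay, with a stated time of 48 h (on this read-out higher numbers stand for weaker inhibition and lower numbers for stronger inhibition), compound 1 gives 29900 nM, and in this assay compound 2 gives 31000 nM; the two values lie within the scatter of each other, so compound 2 holds the higher of the two numbers only nominally, with no real separation from compound 1. Going by the values given here, no step between measured compounds is on record, since the two differ in more than one place. Compound 3 `Cc1ccc(NC(=O)N(Cc2ccccn2)n2cnnc2)cc1` is the next member. Relative to compound 2 the change is 4-methylphenyl in place of benzyl on an amide-type nitrogen; the two have the same atoms, joined differently. Compound 1 carries the same 4-methylphenyl on its amide-type nitrogen and in this assay gives 29900 nM. On that ground the expected step is a 1.0-fold lower number from compound 2 to compound 3 (0.01 log units; within the scatter), none beyond the scatter. For compound 3 the estimate in this assay is 30000 nM, with a range from 12000 nM to 75000 nM.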

Compound 3, half-maximal inhibitory concentration: 35200 nM
For compound 3 the middle estimate is 1.2-fold (0.07 log units) below the measured one, within the range that was stated.
By their numbers in this assay, from the lowest: compounds 1, 2 and 3 (each within the scatter of the next).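

For the compounds shown here, the pair compound 2 and compound 3 gives the only comparison so far that differs in one place. In this assay, 4-methylphenyl in place of benzyl on an amide-type nitrogen whose other neighbour is the carbonyl carbon gives a 1.1-fold higher number from compound 2 to compound 3 (0.06 log units; within the scatter), so at this position the two groups, with the same atoms joined differently, are not told apart on this read-out. No measurement at hand bears on the reason for this.

On these data alone, whether a longer chain in place of benzyl, or an amine or a carboxylic acid in place of the methyl of 4-methylphenyl, would give a step beyond the scatter stays open. Also open is whether any change on this nitrogen can separate members of the series in this assay, since the pair shown does not.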